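Swapping 4-chlorobenzyl for 3-methylbenzyl on a shared core

A few compounds are considered here, and "the series" means these few. Any claim that something is new, unique, unknown or untested is made for them only; others in the source may bear on it.

- compound 1 `CNC(=O)[C@@H](CO)NCc1ccc(OCc2cccc(OC)c2)cc1` gives 109 mg/kg as its measured value
- compound 2 `CNC(=O)[C@@H](CO)NCc1ccc(OCc2ccc(Cl)cc2)cc1` gives 216 mg/kg as its measured value

Both compounds were tested in a functional assay on the whole organism with Mus musculus as the target (on this read-out lower numbers stand for an effect already at smaller amounts and higher numbers for an effect only at larger amounts of compound), and only these two numbers exist so far. Compound 2 at 216 mg/kg lies within the scatter of compound 1, so the pair cannot be ranked. Going by the values given here, the one measured step, a 2.0-fold higher number from compound 1 to compound 2 (0.30 log units; within the scatter) and nothing more, put 4-chlorophenyl in place of 3-methoxyphenyl.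

Compound 3 `CNC(=O)[C@@H](CO)NCc1ccc(OCc2cccc(C)c2)cc1` is the next case. Its difference from compound 2 reads 3-methylphenyl in place of 4-chlorophenyl on a saturated chain carbon bound to an oxygen on an aromatic ring and puts 3-methylphenyl in place of 4-chlorophenyl on a saturated chain carbon bound to an oxygen on an aromatic ring. Among the compounds with values here, the measured step changed the group at this same place, and it is the only evidence available. With that single step inside the scatter, no shift beyond the scatter is expected in this assay for this new swap. The expected step is a 1.4-fold lower number from compound 2 to compound 3 (0.16 log units; within the scatter) and it is small enough to stay inside the scatter. For compound 3 the estimated value is 150 mg/kg with an expected range of 70 mg/kg to 320 mg/kg on this read-out.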

Compound 3, dose for half-maximal effect: 41.3 mg/kg
For compound 3 the middle estimate is 3.6-fold (0.56 log units) above the measured one; the whole stated range lies above it.
By their numbers in this assay, from the lowest: compound 3; then compounds 1 and 2 (each within the scatter of the next).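

In this assay, going by these compounds alone, the group on a saturated chain carbon bound to an oxygen on an aromatic ring clearly matters: putting 3-methylphenyl in place of 4-chlorophenyl gives the first step that lies beyond the scatter (a 5.2-fold lower number from compound 2 to compound 3 (0.72 log units; beyond the scatter)). The narrower change of methyl in place of methoxy on an aromatic carbon also registers (a 2.6-fold lower number from compound 1 to compound 3 (0.42 log units; beyond the scatter)), so compound 3 has the lowest number of the three, with its steps to both other compounds beyond the scatter. These two steps show that a modest change to this ring can shift the dose needed for an effect in the whole animal, but no supporting information explains why.

The step from 4-chlorophenyl to 3-methylphenyl changes both the group on the ring and its place, so the contribution of each remains unresolved, and a 3-chlorophenyl group would help separate them. Also open, going by these compounds, is how far the trend from methoxy to methyl extends, for example to an ethyl group, or whether an amine on the ring would keep the effect at a low dose.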